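Working notes: pyridin-2-yl to 6-methylpyridin-2-yl

This account rests on a few compounds, and the source may have more. Where it says the series, first, only, none or still open, it means among the compounds named here.

In a functional assay on HCT-116 cells (Homo sapiens) for antiproliferative activity (on this read-out higher numbers stand for weaker inhibition and lower numbers for stronger inhibition), compound 1 (`CCc1cc2c(N/N=C\C3CC3)ncnc2s1`) stands at "not determined" (no result reported) and offers no number. Compound 2 (`CC(C)c1cc2c(N/N=C\c3ccccn3)ncnc2s1`) gives 0.01 ug/mL and compound 3 (`CC(C)(C)c1cc2c(N/N=C\c3ccccn3)ncnc2s1`) gives 0.014 ug/mL within the scatter of each other. Compound 4 (`Cc1cccc(/C=N\Nc2ncnc3sc(C(C)(C)C)cc23)n1`) differs from compound 3 by methyl in place of hydrogen on an aromatic carbon in the form of methyl in place of hydrogen on an aromatic carbon, pyridin-2-yl to 6-methylpyridin-2-yl. Among the compounds with values here, no measured step covers this change. The nearest, a 1.4-fold higher number from compound 2 to compound 3 (0.15 log units; within the scatter) for methyl in place of hydrogen on a saturated chain carbon, lies within the scatter, so no step beyond the scatter is expected in this assay here. The expected step is a 1.4-fold higher number from compound 3 to compound 4 (0.15 log units; within the scatter) and remains uncertain. Compound 4 is estimated at 0.02 ug/mL with an expected range of 0.006 ug/mL to 0.07 ug/mL for now.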

Compound 4, half-maximal inhibitory concentration: 0.268 ug/mL
Compound 4: the middle estimate sits 13-fold (1.13 log units) below what was measured; measured number outside the range, above it.
By their numbers in this assay, from the lowest: compounds 2 and 3 (each within the scatter of the next); then compound 4.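

On the pyridin-2-yl ring, one methyl next to the ring nitrogen weighs far more in this assay than the methyl added on the saturated chain, with a 19-fold higher number from compound 3 to compound 4 (1.28 log units; beyond the scatter) for the ring change against a 1.4-fold higher number from compound 2 to compound 3 (0.15 log units; within the scatter) for the chain change. This position is the first in the shown steps where a change moves the number beyond the scatter, and the move is toward weaker inhibition.

Going by these compounds, whether a methoxy, an amine or a fluorine at the same place would cost as much stays open, as does a methyl elsewhere on the ring. No measurement at hand bears on why the methyl has this effect.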